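A few compounds are considered here, and "the series" means these few. Any claim that something is new, unique, unknown or untested is made for them only; others in the source may bear on it.

Measured so far in an assay on isolated protein for inhibition of Nicotinamide phosphoribosyltransferase (Homo sapiens), read by mass spectrometry, with stated times of 15 min and 30 min; on this read-out higher numbers stand for weaker inhibition and lower numbers for stronger inhibition:
compound 1 `O=C(NCc1ccc(S(=O)(=O)c2cc(F)cc(F)c2)cc1)N1Cc2ccncc2C1` gives 7.1 nM;
compound 2 `CCC(=O)N1CCC(S(=O)(=O)c2ccc(CNC(=O)N3Cc4ccncc4C3)cc2)CC1` gives 27 nM.

Among the compounds with values here, compound 2 holds the highest of the two numbers measured; its nearest neighbour is compound 1, and the only measured step, a 3.8-fold higher number from compound 1 to compound 2 (0.58 log units; beyond the scatter), is modest but beyond the scatter.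

Compound 3 `O=C(NCc1ccc(S(=O)(=O)N2CCOCC2)cc1)N1Cc2ccncc2C1` differs from compound 2 by morpholin-4-yl in place of 1-propanoylpiperidin-4-yl on a sulfonyl sulfur. Within the data shown here, the one step that bears on it is the earlier exchange at the same sulfonyl sulfur, a 3.8-fold higher number from compound 1 to compound 2 (0.58 log units; beyond the scatter), where a non-aromatic ring replaced an aromatic one and the number rose. Among the measured compounds shown here, the present change swaps one non-aromatic ring for another with fewer heavy atoms and an additional hetero atom; no measured pair tests that exchange directly, so the direction rests on that single step. From compound 2 the expected step is a 2.2-fold higher number from compound 2 to compound 3 (0.35 log units; beyond the scatter), a modest further rise with a wide range. Compound 3 is therefore estimated in this assay at 60 nM, between 15 nM and 250 nM.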

Compound 3, half-maximal inhibitory concentration: 71 nM
Beside the measured number, compound 3's estimate is 1.2-fold (0.07 log units) below it; the range from low to high includes it.
By their numbers in this assay, from the lowest: compound 1; then compound 2; then compound 3.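

At the sulfonyl sulfur in this assay, morpholin-4-yl in place of 1-propanoylpiperidin-4-yl gives a 2.6-fold higher number from compound 2 to compound 3 (0.42 log units; beyond the scatter), so the number also moves between two non-aromatic rings, and a ring with fewer heavy atoms does not recover the value held by the 3,5-difluorophenyl group. The full exchange of 3,5-difluorophenyl for morpholin-4-yl gives a 10-fold higher number from compound 1 to compound 3 (1.00 log units; beyond the scatter), the widest step yet seen at this position. No measurement available here explains these differences.

The step from compound 2 to compound 3 changes the ring hetero atoms and removes the propanoyl group in one move, so their separate contributions remain unresolved. Still open, going by these compounds, is how plain phenyl, with no fluorine, or piperidin-1-yl on the same sulfonyl sulfur would compare with these groups.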